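Ethyl for Methoxy on a Tetrazole-Bearing Core

The source may report more compounds than this note shows. Statements on the series, on what has been measured and on what is new or still open speak of the compounds shown alone.

Measured so far:
compound 1, `COc1ccc2c(=O)c(-c3nn[nH]n3)c[nH]c2c1`: 10 mg/kg
compound 2, `Fc1cc(F)c2ncc(-c3nn[nH]n3)cc2c1`: 10 mg/kg

In a functional assay on the whole organism (strain Sprague-Dawley) for inhibition, with Rattus norvegicus as the target (a lower number here means that less compound is needed, a higher number that more compound is needed for the effect), compound 1 gives 10 mg/kg. Compound 2, which has a different core, gives 10 mg/kg in this assay, so the two measured compounds stand level at the digits reported, and the data give no order between them; the difference lies within the usual scatter of repeated runs. Among the compounds with values here, no pair of measured compounds differs in only one place, so no single-change step has yet been observed in this assay.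

Compound 3, `CCc1ccc2c(=O)c(-c3nn[nH]n3)c[nH]c2c1`, has not been measured. It differs from compound 1 in one place: ethyl in place of methoxy on an aromatic carbon. Within the data shown here, both groups leaving and entering are small and uncharged, and the measured compounds offer no step from which a direction could be read. The account therefore expects no change beyond the scatter for the step of no change at the digits printed from compound 1 to compound 3 (within the scatter) in this assay. For compound 3 the expected minimum effective dose in this assay is 10 mg/kg, with a range from 3 mg/kg to 30 mg/kg.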

Compound 3, minimum effective dose: < 5 mg/kg
Compound 3: no number, only a limit; the forecaster's own chance of this, stated with the estimate: 10%; middle value at least 2.0-fold (0.30 log units) away from the limit.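

Ethyl in place of methoxy on an aromatic carbon, at the place that is meta to a fused ring and para to a fused ring, gives the first single-change step in this assay: an at least 2.0-fold lower number from compound 1 to compound 3 (0.30 log units; that floor lies within the scatter). Compound 3 gives < 5 mg/kg, which is a limit of the assay and not a number, so the step has only a floor, and that floor lies within the scatter: the limit of < 5 mg/kg in this assay, at which 1 of the 3 values shown sits. Even so, the result shows something compounds 1 and 2 could not: methoxy, with its oxygen and its hydrogen-bond acceptor, can give way to ethyl, which has neither, without the minimum effective dose of the shared core rising.

Going by these compounds, how far the true dose of compound 3 lies under its limit remains open, and with it whether this step goes beyond the scatter at all. Also open, on these data alone, is whether a longer chain such as propyl, a chlorine atom or an amine at this same place would keep the dose where compound 3 stands.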